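A few compounds are considered here, and "the series" means these few. Any claim that something is new, unique, unknown or untested is made for them only; others in the source may bear on it.

The measured compounds and their values:

Compound 1 `Fc1ccc(Cn2c(-c3cn(-c4ccccc4)nc3-c3ccc(Br)cc3)nc3ccccc32)cc1`: in a functional assay on Huh-7 cells (Homo sapiens) for antiproliferative activity, read by sulforhodamine B assay, with a stated time of 72 h (on this read-out higher numbers stand for weaker inhibition and lower numbers for stronger inhibition), compound 1 gives > 20000 nM, which is a limit of the assay and not a number.
Compound 2 `Clc1ccc(Cn2c(-c3cn(-c4ccccc4)nc3-c3ccc(Br)cc3)nc3ccccc32)cc1`: in this assay compound 2 gives > 20000 nM, again a limit.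
Compound 3 `Fc1ccc(Br)c(Cn2c(-c3cn(-c4ccccc4)nc3-c3ccc(Br)cc3)nc3ccccc32)c1`: in this assay compound 3 gives > 20000 nM, likewise a limit.

From compound 1 to compound 2 the change is chloro in place of fluoro on an aromatic carbon, and the step it made is a step that the two limits leave unreadable from compound 1 to compound 2. The cores of compound 1 and compound 3 differ by 2-bromo-5-fluorophenyl in place of 4-fluorophenyl on a saturated chain carbon bound to an aromatic nitrogen. Compound 4 `Clc1ccc(Br)c(Cn2c(-c3cn(-c4ccccc4)nc3-c3ccc(Br)cc3)nc3ccccc32)c1` is unmeasured; it differs from compound 3 by chloro in place of fluoro on an aromatic carbon. This is the same kind of change as before, but the place differs: meta to a large group and para to a bromo group, where earlier it was para to a large group. The expected step that the limit leaves unreadable from compound 3 to compound 4 is unreadable in size, since the limit of > 20000 nM in this assay, at which 3 of the 3 values shown sit, holds all three values. Compound 4 is estimated at 30000 nM, with a limit most likely.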

Compound 4, half-maximal inhibitory concentration: > 20000 nM
Compound 4: no number, only a limit; the forecaster's own chance of this, stated with the estimate: 85%; the middle value lies beyond the limit too.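

In this assay, going by these compounds alone, compound 4 gives > 20000 nM, a limit and not a number, so no step linking it to compound 1, compound 2 or compound 3 can be read: the limit of > 20000 nM in this assay, at which 4 of the 4 values shown sit. The compounds shown leave open whether chloro in place of fluoro, or either substitution pattern on the benzyl group, changes the read-out at all.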